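The source may report more compounds than this note shows. Statements on the series, on what has been measured and on what is new or still open speak of the compounds shown alone.

Compound 1 `O=C1c2c[n+]([O-])c3ccccc3c2C(=O)c2c1c1ccccc1n2CCCCn1ccnc1`: 130 nM
Compound 2 `O=C1c2c[n+]([O-])c3ccccc3c2C(=O)c2c1c1ccccc1n2Cc1cn([C@@H]2C[C@H](O)[C@@H](CO)O2)nn1`: 110 nM

Among the compounds with values here, in a functional assay on MCF7 cells (Homo sapiens) for cytotoxicity, read by MTT assay, with a stated time of 72 h (a lower number here means a stronger inhibitor, a higher number a weaker inhibitor), the two measured compounds cannot be told apart: compound 1 and compound 2 lie within the usual scatter of each other, so compound 1 stands level with the only other number available. Compound 3 `CN1CCN(CCCCn2c3c(c4ccccc42)C(=O)c2c[n+]([O-])c4ccccc4c2C3=O)CC1` shares the core of compound 1 and differs in one place: 4-methylpiperazin-1-yl in place of 1H-imidazol-1-yl on a saturated chain carbon, four bonds along the chain from an aromatic nitrogen. Within the data shown here, no measured pair shows this change, so no step beyond the scatter is expected in this assay, and no direction can be favoured. The expected step is a 1.2-fold higher number from compound 1 to compound 3 (0.06 log units; within the scatter). For compound 3 the estimated value is 150 nM, within an expected range of 50 nM to 450 nM.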

Compound 3, half-maximal inhibitory concentration: 100 nM
Compound 3: middle estimate off by 1.5-fold (0.18 log units), on the high side; measured number inside the range.
By their numbers in this assay, from the lowest: compounds 3, 2 and 1 (each within the scatter of the next).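

In this assay, 4-methylpiperazin-1-yl in place of 1H-imidazol-1-yl on a saturated chain carbon gives a 1.3-fold lower number from compound 1 to compound 3 (0.11 log units; within the scatter). This first pair differing in one place shows that, at this position, a six-membered non-aromatic ring and a five-membered aromatic ring cannot be told apart in this assay. No measurement shown accounts for this result. As far as these compounds go, whether a carboxylic acid or an open-chain dimethylamino group at the end of the chain would give a step beyond the scatter remains open. So does the effect of a shorter or longer chain carrying 4-methylpiperazin-1-yl.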